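Swapping the Fluorine Pattern on a Pyrazole Amide Core

This account rests on a few compounds, and the source may have more. Where it says the series, first, only, none or still open, it means among the compounds named here.

Compound 1, `CC1(C)c2[nH]nc(NC(=O)c3ccccc3)c2CN1Cc1cc(F)cc(F)c1`, gives 190 nM in an assay on Sf21 cells for inhibition of high affinity nerve growth factor receptor (Homo sapiens), read by HTRF, with a stated time of 30 min, in the presence of a further agent that is not named here; on this read-out higher numbers stand for weaker inhibition and lower numbers for stronger inhibition.
Compound 2, `CN1CCN(c2cccc(C(=O)Nc3n[nH]c4c3CN(Cc3cccc(F)c3F)C4(C)C)c2)CC1`, gives 210 nM in this assay.

Of the two numbers, compound 2 gives the larger, yet its gap to compound 1 lies within the scatter of repeated measurements, so the two are not told apart. Compound 3, `CN1CCN(c2cccc(C(=O)Nc3n[nH]c4c3CN(Cc3cc(F)cc(F)c3)C4(C)C)c2)CC1`, carries the change (3,5-difluorophenyl in place of 2,3-difluorophenyl on a saturated chain carbon bound to an amine nitrogen in a ring), which brings it the benzyl group already present in compound 1. The two measured compounds show no spread beyond the scatter, so compound 3 is expected to stay close to compound 2, with a step of a 1.2-fold lower number from compound 2 to compound 3 (0.07 log units; within the scatter) in this assay. Compound 3 is therefore estimated at 180 nM, in the range 70 nM to 450 nM.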

Compound 3, half-maximal inhibitory concentration: 150 nM
The estimate for compound 3 lay 1.2-fold (0.08 log units) above the measured number, and the stated range covers the measured number.
By their numbers in this assay, from the lowest: compounds 3, 1 and 2 (each within the scatter of the next).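

In this assay, the change from 2,3-difluorobenzyl to 3,5-difluorobenzyl gives a 1.4-fold lower number from compound 2 to compound 3 (0.15 log units; within the scatter), so the two fluorine patterns at this position are not told apart. With 3,5-difluorobenzyl held fixed, 4-methylpiperazin-1-yl in place of hydrogen on an aromatic carbon gives a 1.3-fold lower number from compound 1 to compound 3 (0.10 log units; within the scatter), and these two compounds are not told apart either. No supporting data bear on these results. On these data alone, whether a chlorine or a methoxy group on the benzyl ring would move the number beyond the scatter stays open. So does the effect of a morpholine in place of 4-methylpiperazin-1-yl.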